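The compounds below may be only part of what the source reports. "The series", "measured", "known", "first", "only" and "open" are said of these compounds alone.

Compound 3 `COc1ccc([C@@H]2C/C(=N/OCc3cn(-c4cc(OC)c(OC)c(OC)c4)nn3)c3cc(CC=C(C)C)c(OC)cc3O2)cc1` gives 36% in a functional assay on PC-3 cells (Homo sapiens) for inhibition, read by sulforhodamine B assay, with a stated time of 48 h, tested at 50 uM (a lower number here means less inhibition of growth, a higher number more inhibition of growth at the concentration tested), the lowest of the three numbers measured, though the value of compound 2 `COc1ccc([C@@H]2C/C(=N/OCc3cn(-c4ccc(C(=O)c5ccccc5)cc4)nn3)c3cc(CC=C(C)C)c(OC)cc3O2)cc1`, 40%, lies within the scatter of it. Compound 1 `COc1ccc([C@@H]2C/C(=N/OCc3cn(-c4ccc(Cl)cc4C)nn3)c3cc(CC=C(C)C)c(OC)cc3O2)cc1` gives 49%, and the step of a number 13 percentage points lower from compound 1 to compound 3 (beyond the scatter) is the only one beyond the scatter. Compound 4 `COc1ccc([C@@H]2C/C(=N/OCc3cn(-c4ccc(C(N)=O)cc4)nn3)c3cc(CC=C(C)C)c(OC)cc3O2)cc1` differs from compound 3 only on the aromatic nitrogen: 4-carbamoylphenyl in place of 3,4,5-trimethoxyphenyl on an aromatic nitrogen. For the measured compounds named here, no measured step covers this exchange; the single bearing step, from a chloro-methylphenyl to the trimethoxyphenyl, was modest and downward. With three aryl groups giving numbers spread over a narrow band, compound 4 is expected to fall in the same band, with a step of a number 3 percentage points higher from compound 3 to compound 4 (within the scatter) that is not expected to exceed the scatter. Compound 4 is therefore estimated at 39%, between 26% and 52%.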

Compound 4, percent growth inhibition at one concentration: 100%
Beside the measured number, compound 4's estimate is 61 percentage points below it; measured number outside the range, above it.
By their numbers in this assay, from the lowest: compounds 3, 2 and 1 (each within the scatter of the next, the first and the last beyond it); then compound 4.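

In this assay the group on the aromatic nitrogen, so far linked only to a modest shift, now carries a large one: there is a number 64 percentage points higher from compound 3 to compound 4 (beyond the scatter) and also a number 51 percentage points higher from compound 1 to compound 4 (beyond the scatter) on the same exchange of aryl group. Keeping the carbonyl and changing only what it bears gives a number 60 percentage points higher from compound 2 to compound 4 (beyond the scatter) here, so the gain goes with the amino group on that carbonyl and not with the carbonyl alone. Nothing measured here explains this rise. The compounds shown leave open whether a methylamino group, a dimethylamino group or a hydroxyl on that carbonyl would serve as well.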